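Swapping the Amide for a Sulfonamide in Compound 2

A few compounds are considered here, and "the series" means these few. Any claim that something is new, unique, unknown or untested is made for them only; others in the source may bear on it.

Compound 2 `COc1ccc(C(=O)Nc2cccc3c2N(S(=O)(=O)c2ccc(OC)cc2)CC3)cc1` is examined in a functional assay on KB cells (Homo sapiens) for cytotoxicity (on this read-out lower numbers stand for stronger inhibition and higher numbers for weaker inhibition), where compound 2 gives 2600 nM. Compound 1 `COc1ccc(S(=O)(=O)N2CCc3cc(Br)cc(NC(=O)c4ccco4)c32)cc1` gives 89 nM in this assay, so compound 2 stands with the higher of the two numbers. Compound 3 `COc1ccc(S(=O)(=O)N2CCc3cccc(NCc4ccccc4)c32)cc1` reaches only the limit > 10000 nM in this assay. Going by the values given here, the one measured step, an at least 3.8-fold higher number from compound 2 to compound 3 (0.58 log units; beyond the scatter), shows that exchanging the carbonyl-bearing group for benzyl weakens inhibition; its size rests on (the limit of > 10000 nM in this assay, at which 1 of the 3 values shown sits). Compound 4 `COc1ccc(S(=O)(=O)N2CCc3cccc(NS(=O)(=O)c4ccccc4)c32)cc1` differs from compound 2 by phenylsulfonyl in place of (4-methoxyphenyl)carbonyl on a nitrogen on an aromatic ring. Phenylsulfonyl, like (4-methoxyphenyl)carbonyl, carries two hydrogen-bond acceptors and no donor, so a smaller shift than in the measured step is expected. Compound 4 is therefore expected to give 4000 nM, between 1300 nM and 12000 nM. The expected step of a 1.5-fold higher number from compound 2 to compound 4 (0.19 log units; within the scatter) is a modest weakening.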

Compound 4, half-maximal inhibitory concentration: 650 nM
Estimate against measurement, compound 4: 6.2-fold (0.79 log units) above, and the stated range ends above it.
By their numbers in this assay, from the lowest: compound 1; then compound 4; then compound 2. At a limit, above all of these: compound 3.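

In this assay, phenylsulfonyl in place of (4-methoxyphenyl)carbonyl on this nitrogen gives a 4.0-fold lower number from compound 2 to compound 4 (0.60 log units; beyond the scatter), so two groups with the same count of hydrogen-bond donors and acceptors are not interchangeable here. Phenylsulfonyl in place of benzyl gives an at least 15-fold lower number from compound 3 to compound 4 (1.18 log units; beyond the scatter), which separates all three groups on the shared core. That step's size is only a bound, as compound 3 stands at a limit: the limit of > 10000 nM in this assay, at which 1 of the 4 values shown sits.

The change removes both the carbonyl and the methoxy group, and the compounds shown do not separate the two. A plain benzoyl group on this nitrogen would do so.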